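Dimethylphenyl isomers compared for chromatographic lipophilicity

The source may report more compounds than this note shows. Statements on the series, on what has been measured and on what is new or still open speak of the compounds shown alone.

Compound 1 `COc1ccc2nc(C)cc(OCC(=O)Nc3cccc(C)c3)c2c1`: 4.83
Compound 2 `COc1ccc2nc(C)cc(OCC(=O)Nc3cc(C)ccc3C)c2c1`: 5.05

In a physicochemical assay for lipophilicity, read by HPLC, in phosphate buffer, measured as chromatographic lipophilicity, at pH 7.4 (on this read-out lower numbers stand for lower lipophilicity and higher numbers for higher lipophilicity), compound 1 gives 4.83. Compound 2 gives 5.05, the highest of the two numbers, though the gap to compound 1 is within the scatter. Going by the values given here, the single measured step, a number 0.22 log units higher from compound 1 to compound 2 (within the scatter), is methyl in place of hydrogen on an aromatic carbon and is likewise within the scatter.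

Compound 3 `COc1ccc2nc(C)cc(OCC(=O)Nc3c(C)cccc3C)c2c1` is not yet measured. It differs from compound 2 by 2,6-dimethylphenyl in place of 2,5-dimethylphenyl on an amide-type nitrogen; the two have the same atoms, joined differently. The step from compound 1 to compound 2 bears on this only loosely: it added a methyl, whereas here no atom is added or removed. Since the measured step stayed within the scatter, compound 3 is expected to stay close to compound 2, with a number 0.10 log units lower from compound 2 to compound 3 (within the scatter) expected to lie within the scatter. Compound 3 is therefore estimated at 4.95, with a range from 4.65 to 5.3.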

Compound 3, distribution coefficient: 4.55
Estimate against measurement, compound 3: 0.40 log units above; the whole stated range lies above it.
By their numbers in this assay, from the lowest: compounds 3, 1 and 2 (each within the scatter of the next, the first and the last beyond it).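

Swapping 2,5-dimethylphenyl for 2,6-dimethylphenyl on the amide-type nitrogen gives the first step beyond the scatter in this assay, a number 0.50 log units lower from compound 2 to compound 3 (beyond the scatter), even though both groups have the same heavy atoms and the same counts of donors and acceptors. The arrangement of the two methyl groups on this ring therefore changes the read-out with no atom added or removed, which the earlier step, a methyl in place of hydrogen, could not show. The other new step, a number 0.28 log units lower from compound 1 to compound 3 (within the scatter), stays within the scatter, so 2,6-dimethylphenyl and 3-methylphenyl are not told apart here.

Nothing at hand bears on why the arrangement of the methyl groups matters here. From the compounds shown here alone, it also remains open whether a phenyl ring carrying chlorine or methoxy in place of the methyl groups would follow the same course.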